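Fluoro in Place of Methoxy: An Expected Clearance Step

The source may report more compounds than this note shows. Statements on the series, on what has been measured and on what is new or still open speak of the compounds shown alone.

Measured compounds:
- compound 1, `COc1ccc(-c2c(S(=O)(=O)c3ccc(F)c(Cl)c3)cnc3cc(F)ccc23)cc1`, 1.08 mL/min
- compound 2, `COc1ccc(-c2c(S(=O)(=O)c3cc(Cl)cc(Cl)c3)cnc3cc(F)ccc23)cc1`, 1 mL/min
- compound 3, `COc1ccc(-c2c(S(=O)(=O)c3ccc(OC)cc3)cnc3cc(F)ccc23)cc1`, 1.18 mL/min

Three compounds sharing one core were tested in an ADME assay on microsomes from liver (Homo sapiens) for metabolic stability, tested at 2.5 uM; on this read-out higher numbers stand for fast clearance and lower numbers for slow clearance. Compound 1 stands second highest of the three numbers, but all three lie close together: the change a 1.1-fold lower number from compound 1 to compound 2 (0.03 log units; within the scatter) and the change a 1.1-fold higher number from compound 1 to compound 3 (0.04 log units; within the scatter) are both within the scatter, as is a 1.2-fold higher number from compound 2 to compound 3 (0.07 log units; within the scatter). Each of these steps alters only the aryl group on the sulfonyl sulfur, and none of them moves the number by more than repeated measurement would.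

Compound 4, `O=S(=O)(c1ccc(F)c(Cl)c1)c1cnc2cc(F)ccc2c1-c1ccc(F)cc1`, is not yet measured. It differs from compound 1 in one place: fluoro in place of methoxy on an aromatic carbon. Among the compounds with values here, this change sits on the other aryl ring, not on the sulfonyl sulfur, so no measured step bears on it directly. What the measured steps do show is that varying an aryl substituent on this core left this assay unmoved. On that basis compound 4 is expected to give 1 mL/min, with a range from 0.6 mL/min to 1.8 mL/min, which means an expected step of a 1.1-fold lower number from compound 1 to compound 4 (0.03 log units; within the scatter), that is, no step beyond the scatter in either direction.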

Compound 4, intrinsic clearance in a liver preparation (reported as CLH), per the amount of preparation that the assay uses: 0.69 mL/min
Compound 4: the middle estimate sits 1.4-fold (0.16 log units) above what was measured, and the stated range covers the measured number.
By their numbers in this assay, from the lowest: compounds 4, 2, 1 and 3 (each within the scatter of the next).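

Within the data shown here, the earlier compounds varied only the aryl group on the sulfonyl sulfur, so this is the first look at the other aryl ring, where fluoro replaces methoxy on an aromatic carbon para to a large group. In this assay this exchange gives a 1.6-fold lower number from compound 1 to compound 4 (0.19 log units; within the scatter) and so does not separate the two groups, which means this second site, like the sulfonyl side across compounds 1, 2 and 3, shows no change that repeated measurement could not produce on its own. No supporting measurement is available here to explain how either group behaves in this preparation.

Methoxy and fluoro are only two small groups, so it remains open whether the same position would stay as quiet with an amine, a carboxylic acid or a longer chain such as butoxy in their place. Going by these compounds, it is also open whether 4-methoxyphenyl to 4-fluorophenyl would read the same with the sulfonyl groups of compound 2 or compound 3, since this exchange appears here only with the sulfonyl group of compound 1.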